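This account rests on a few compounds, and the source may have more. Where it says the series, first, only, none or still open, it means among the compounds named here.

Measured compounds in an assay on isolated protein for binding affinity to leukotriene B4 receptor 1 (Homo sapiens), tested at 1 uM; on this read-out lower numbers stand for less inhibition and higher numbers for more inhibition at the one concentration tested (going by the name of the read-out):
compound 1, `CC(=O)c1ccc(OCCCCC#N)cc1O` — 0%
compound 2, `C=CCc1cc(C(C)=O)c(O)cc1OCCCCC#N` — 57%

Compound 2 stands highest of the two numbers in this assay; its nearest neighbour is compound 1, and the step of a number 57 percentage points higher from compound 1 to compound 2 (beyond the scatter) is beyond the scatter. Compound 3, `C=CCc1cc(C(C)=O)c(O)cc1OCCCCCC(C)(C)O`, has not yet been measured. It differs from compound 2 in one place: 2-hydroxy-2-methylpropyl in place of cyano on a saturated chain carbon, four bonds along the chain from an oxygen on an aromatic ring. Going by the values given here, the only measured step, a number 57 percentage points higher from compound 1 to compound 2 (beyond the scatter), concerns an allyl group on an aromatic carbon, a different position from the chain end that changes here, so it does not bear on the step from compound 2 to compound 3. With nothing in the data to anchor the chain-end change, compound 3 is expected to remain near compound 2, with the step of a number 3 percentage points higher from compound 2 to compound 3 (within the scatter) expected to fall within the scatter. For compound 3 the estimate in this assay is 60%, ranging from 30% to 85%.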

Compound 3, a percentage reported as inhibition, at one concentration (the size of the read-out at that concentration, not a potency): 60%
Compound 3: the middle estimate sits on the measured number at the digits printed, and the stated range covers the measured number.
By their numbers in this assay, from the lowest: compound 1; then compounds 2 and 3 (each within the scatter of the next).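

Exchanging cyano for 2-hydroxy-2-methylpropyl on a saturated chain carbon, four bonds along the chain from an oxygen on an aromatic ring, gives a number 3 percentage points higher from compound 2 to compound 3 (within the scatter) in this assay. At this position, then, a group of 2 heavy atoms with no hydrogen-bond donor and a group of 5 heavy atoms with a hydrogen-bond donor read alike, whereas the earlier step spoke only to allyl on an aromatic carbon. No supporting data accompany this result to explain why the two chain ends match.

As far as these compounds go, whether a carboxylic acid, an amine or a longer chain at this chain end would read the same remains open. Also open, from the compounds shown here alone, is whether the 2-hydroxy-2-methylpropyl compound would keep its reading with hydrogen in place of allyl on the aromatic carbon.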